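The source may report more compounds than this note shows. Statements on the series, on what has been measured and on what is new or still open speak of the compounds shown alone.

- Compound 1 `OC(c1ccc(Cl)cc1)(c1ccc(Br)cc1)c1cccnc1`: 57000 nM
- Compound 2 `Cc1ccccc1C(O)(c1ccc(Cl)cc1)c1cccnc1`: 82000 nM

In an ADME assay on L6 cells (Rattus norvegicus) for cytotoxicity, read by resazurin assay, with a stated time of 72 h (a higher number here means a weaker inhibitor, a lower number a stronger inhibitor), compound 1 gives 57000 nM and compound 2 gives 82000 nM. Among the compounds with values here, these two values lie within the scatter of each other, so compound 1 stands level with the only other measured compound.

The compound awaiting measurement is compound 3 `CC(C)Oc1ccc(C(O)(c2ccc(Cl)cc2)c2cccnc2)cc1`. It keeps the core of compound 1 but carries isopropoxy in place of bromo on an aromatic carbon, para to a large group: isopropoxy in place of bromo on an aromatic carbon.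

Within the data shown here, one measured step bears on this change. Moving to 2-methylphenyl in place of 4-bromophenyl gives a 1.4-fold higher number from compound 1 to compound 2 (0.16 log units; within the scatter), a step that also removes the 4-bromophenyl group and stays within the scatter. Among the measured compounds shown here, no measured compound carries isopropoxy, so this single step is thin evidence. Even so, no shift beyond the scatter is expected in this assay, and no direction can be favoured.

The expected step is a 1.1-fold lower number from compound 1 to compound 3 (0.06 log units; within the scatter). For compound 3 the estimated value is 50000 nM, with an expected range from 22000 nM to 110000 nM.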

Compound 3, half-maximal inhibitory concentration: 56600 nM
Beside the measured number, compound 3's estimate is 1.1-fold (0.05 log units) below it, within the range that was stated.
By their numbers in this assay, from the lowest: compounds 3, 1 and 2 (each within the scatter of the next).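

Within the data shown here, compound 3 gives the first reading of a change at this one position, on an aromatic carbon para to a large group. The earlier step, a 1.4-fold higher number from compound 1 to compound 2 (0.16 log units; within the scatter), replaced the whole 4-bromophenyl group rather than only its bromo. In this assay, isopropoxy in place of bromo gives a 1.0-fold lower number from compound 1 to compound 3 (0.00 log units; within the scatter), so the 4 heavy atoms and the hydrogen-bond acceptor of isopropoxy, in place of the 1 heavy atom of bromo, leave the number within the scatter. No measurement here accounts for this result, so the reading stops at the numbers themselves.

Going by these compounds, the three compounds cover only bromo, isopropoxy and the 2-methylphenyl replacement, all within the scatter of one another, so it stays open whether an amine or a carboxylic acid at this position would give a number beyond the scatter in this assay. It is equally open whether a chain longer than isopropoxy would do so, and the compounds shown give no reading of any change to the hydroxyl or the chloro elsewhere on the shared core.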